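A few compounds are considered here, and "the series" means these few. Any claim that something is new, unique, unknown or untested is made for them only; others in the source may bear on it.

Compound 1 `N#Cc1c(N)nc(SCc2cccnc2)c(C#N)c1-c1ccc(OCC2CC2)cc1`: in an assay on CHO cells for displacement of a labelled ligand from adenosine receptor A1 (Homo sapiens), read by scintillation counting, with a stated time of 90 min (on this read-out lower numbers stand for stronger inhibition and higher numbers for weaker inhibition), compound 1 gives 67 nM.
Compound 2 `N#Cc1c(N)nc(SCc2ncc[nH]2)c(C#N)c1-c1ccc(OCC2CC2)cc1`: in this assay compound 2 gives 235 nM.
Compound 3 `N#Cc1c(N)nc(SCC(=O)NO)c(C#N)c1-c1ccc(OCC2CC2)cc1`: in this assay compound 3 gives 536 nM.

Compound 3 has the highest number of the three in this assay, with compound 2 nearest and compound 1 furthest; both of those steps lie beyond the scatter, so compound 3 is the weakest of the measured set. Compound 4 `N#Cc1c(N)nc(SCc2csc(N)n2)c(C#N)c1-c1ccc(OCC2CC2)cc1` has not yet been measured. It differs from compound 3 in one place: 2-amino-1,3-thiazol-4-yl in place of hydroxycarbamoyl on a saturated chain carbon bound to a sulfur. Among the measured compounds shown here, two measured steps bear on this change, since each of them replaced an aromatic ring on the same chain carbon by the hydroxycarbamoyl group: an 8.0-fold higher number from compound 1 to compound 3 (0.90 log units; beyond the scatter) and a 2.3-fold higher number from compound 2 to compound 3 (0.36 log units; beyond the scatter). Reversing that direction, from the hydroxycarbamoyl group back to a ring, should therefore lower the number in this assay by a modest amount. The entering group carries one five-membered aromatic ring with 2 hetero atoms, as compound 2 does, so compound 4 is expected to land nearer compound 2 than compound 1, and the expected step is a 3.0-fold lower number from compound 3 to compound 4 (0.47 log units; beyond the scatter). Compound 4 is thus estimated at 180 nM, within a range from 70 nM to 450 nM.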

Compound 4, inhibition constant: 140 nM
Compound 4: the middle estimate sits 1.3-fold (0.11 log units) above what was measured; low and high end bracket the measured number.
By their numbers in this assay, from the lowest: compound 1; then compounds 4 and 2 (each within the scatter of the next); then compound 3.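

A second five-membered aromatic ring with 2 hetero atoms on the saturated chain carbon bound to a sulfur shows that a lower number than the hydroxycarbamoyl group gives is not particular to the 1H-imidazol-2-yl group: in this assay the change to 2-amino-1,3-thiazol-4-yl gives a 3.8-fold lower number from compound 3 to compound 4 (0.58 log units; beyond the scatter). The two five-membered rings cannot be told apart in this assay, as a 1.7-fold lower number from compound 2 to compound 4 (0.22 log units; within the scatter) stays within the scatter. The pyridin-3-yl group still stands apart from the 2-amino-1,3-thiazol-4-yl group, with a 2.1-fold higher number from compound 1 to compound 4 (0.32 log units; beyond the scatter), so compound 1 remains the strongest of the four.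

As far as these compounds go, whether the amino group on the thiazole contributes, and how a simple phenyl ring or a carboxylic acid on this chain carbon would compare, remains open. Nothing given here explains the order of these groups.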